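A few compounds are considered here, and "the series" means these few. Any claim that something is new, unique, unknown or untested is made for them only; others in the source may bear on it.

Compound 2 `O=C(/C=C/c1ccc(N2CCCC2)cc1)c1ccc(O)cc1` gives 60% in an assay on isolated protein for inhibition of DNA topoisomerase 1 (Homo sapiens), tested at 20 uM; on this read-out higher numbers stand for a stronger effect at the one concentration tested and lower numbers for a weaker effect. Compound 1 `COc1ccc(/C=C/C(=O)c2ccco2)cc1Br` gives 8.8% in this assay, and compound 3 `COc1ccc(/C=C/C(=O)c2ccc(O)cc2)cc1Br` gives 6.6% in this assay. Compound 3 thus stands lowest of the three numbers; the value of compound 1 lies within the scatter of it, while the value of compound 2 lies beyond the scatter above it. Compound 4 `COc1ccc(/C=C/C(=O)c2ccc(F)cc2)cc1Br` differs from compound 3 by fluoro in place of hydroxy on an aromatic carbon. Within the data shown here, no pair of measured compounds differs by this change alone, so no measured step shows its effect. The step is expected to be none beyond the scatter, estimated as a number 1.4 percentage points higher from compound 3 to compound 4 (within the scatter). Compound 4 is therefore expected to give about 8% in this assay, between 0% and 20%.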

Compound 4, a percentage reported as inhibition, at one concentration (the size of the read-out at that concentration, not a potency): 20.1%
Compound 4: the middle estimate sits 12.1 percentage points below what was measured, outside the stated range (above it).
By their numbers in this assay, from the lowest: compounds 3 and 1 (each within the scatter of the next); then compound 4; then compound 2.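

The first step read at this place, an aromatic carbon para to a large group, shows that the group there can shift the result in this assay: fluoro in place of hydroxy gives a number 13.5 percentage points higher from compound 3 to compound 4 (beyond the scatter) and this step is modest. A change of one heavy atom on this ring is therefore enough to move the number beyond the scatter. Nothing available explains the step.

From the compounds shown here alone, it remains open how an amine or a carboxylic acid at this place would compare with fluoro. Going by these compounds, whether the same change would give a similar step on the core of compound 2 also remains open.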